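Quinazoline anilines: moving the methoxy group around the ring

The source may hold more compounds than are shown below. What is called first, only, known or untested is meant among the compounds shown, and "the series" means these compounds.

Measured compounds:
Compound 1, `Fc1cccc(-c2nc(Nc3ccccc3)c3cc(F)ccc3n2)c1`: 49700 nM
Compound 2, `COc1ccc(Nc2nc(-c3cccc(F)c3)nc3ccc(F)cc23)cc1`: 48400 nM

Of the compounds shown here, two have been tested in a functional assay on MCF7 cells (Homo sapiens) for cytotoxicity, read by MTT assay, with a stated time of 48 h; a higher number here means a weaker inhibitor, a lower number a stronger inhibitor. Compound 1 gives 49700 nM in this assay, and compound 2 gives 48400 nM. Among the compounds with values here, compound 2 carries the lower of the two numbers, but its only neighbour is compound 1, and the step of a 1.0-fold lower number from compound 1 to compound 2 (0.01 log units; within the scatter) falls within the scatter, so the two compounds cannot be told apart on these data.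

Compound 3, `COc1ccccc1Nc1nc(-c2cccc(F)c2)nc2ccc(F)cc12`, has not yet been measured. It differs from compound 2 in one place: 2-methoxyphenyl in place of 4-methoxyphenyl on a nitrogen on an aromatic ring. Within the data shown here, no measured step addresses this rearrangement; the only step available, from compound 1 to compound 2, concerns the presence of the methoxy group rather than its placement, and that step was a 1.0-fold lower number from compound 1 to compound 2 (0.01 log units; within the scatter), within the scatter. With no evidence that the methoxy group matters at all in this assay, the expectation for compound 3 is no step beyond the scatter, a 1.0-fold lower number from compound 2 to compound 3 (0.00 log units; within the scatter). Compound 3 is therefore estimated at 48000 nM in this assay, with a range from 20000 nM to 115000 nM.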

Compound 3, half-maximal inhibitory concentration: > 50000 nM
Compound 3: only a limit was reported (the forecaster's own chance of this, stated with the estimate: 10%); middle value at least 1.0-fold (0.01 log units) from the limit.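

Compound 3 is reported in this assay only as a limit, > 50000 nM. Placing 2-methoxyphenyl in place of 4-methoxyphenyl on the nitrogen gives an at least 1.0-fold higher number from compound 2 to compound 3 (0.01 log units; that floor lies within the scatter); this floor does not show that the placement of the methoxy group matters, and the true size of the step stays unknown. Methoxy in place of hydrogen on an aromatic carbon gives a number no lower from compound 1 to compound 3 (the limit leaves the size open). Neither methoxyphenyl group has thus been shown to give a number set apart from that of compound 1, and the series now includes a result without an exact value: the limit of > 50000 nM in this assay, at which 1 of the 3 values shown sits.

The compounds shown leave open how far compound 3 truly lies from compound 2, and whether any change on this aniline ring can bring the number clearly down in this assay. They also leave open what a different group in the place of the methoxy, such as an amine or a carboxylic acid, would do on the same core.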